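The source may report more compounds than this note shows. Statements on the series, on what has been measured and on what is new or still open speak of the compounds shown alone.

In an ADME assay on HOS cells (Homo sapiens) for cytotoxicity, read by luminescence and ATP content, with a stated time of 48 h (on this read-out higher numbers stand for lower toxicity in this test and lower numbers for higher toxicity in this test), compound 2 `Nc1c(C(=O)NCc2ccc(F)cc2F)c(=O)n(O)c2ncc(CCc3ccccc3)cc12` gives 18000 nM as its half-maximal cytotoxic concentration. Level with it stands compound 1 `Nc1c(C(=O)NCc2ccc(F)cc2F)c(=O)n(O)c2ncc(CCCCc3ccccc3)cc12` at 13000 nM in the same test, and a 1.4-fold higher number from compound 1 to compound 2 (0.14 log units; within the scatter) separates them. Compound 3 `Nc1c(C(=O)NCc2ccc(F)cc2F)c(=O)n(O)c2ncc(CCC(=O)O)cc12` gives > 250000 nM here, which is a limit of the assay and not a number.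

Compound 4 `Nc1c(C(=O)NCc2ccc(F)cc2F)c(=O)n(O)c2ncc(CCC(=O)NCCO)cc12` is still unmeasured, and (2-hydroxyethyl)carbamoyl in place of phenyl on a saturated chain carbon, two bonds along the chain from an aromatic carbon is what separates it from compound 2. In words, this is (2-hydroxyethyl)carbamoyl in place of phenyl on a saturated chain carbon, two bonds along the chain from an aromatic carbon.

Within the data shown here, two measured steps bear on this change. Putting carboxy in place of phenyl gave an at least 13-fold higher number from compound 2 to compound 3 (1.14 log units; beyond the scatter) and putting carboxy in place of phenethyl gave an at least 19-fold higher number from compound 1 to compound 3 (1.28 log units; beyond the scatter) and both of these are large. Both steps rest on the limit of > 250000 nM in this assay, at which 1 of the 3 values shown sits, rather than on a number.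

Compound 4 loses the phenyl too, so on the strength of an at least 13-fold higher number from compound 2 to compound 3 (1.14 log units; beyond the scatter) a large rise is expected in this assay even though the entering group is not carboxy. The step expected is a 5.6-fold higher number from compound 2 to compound 4 (0.74 log units; beyond the scatter) and it would mean lower toxicity in this test. Compound 4 is expected at 100000 nM within an estimated range of 30000 nM to 250000 nM in this test.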

Compound 4, half-maximal cytotoxic concentration: > 250000 nM
Compound 4: a limit, no number; the forecaster's own chance of this, stated with the estimate: 35%; middle value at least 2.5-fold (0.39 log units) away from the limit.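

Until now, carboxy in compound 3 was the only group without a phenyl ring shown at this saturated chain carbon, so the large rise might have belonged to that one group. The uncharged (2-hydroxyethyl)carbamoyl group also gives a large change in this assay, with an at least 13-fold higher number from compound 2 to compound 4 (1.14 log units; beyond the scatter) and an at least 19-fold higher number from compound 1 to compound 4 (1.28 log units; beyond the scatter), which here means lower toxicity in this test. Among these four compounds, the two with a phenyl ring at the end of the chain therefore give the low numbers, and the two with a carbonyl-bearing group and no ring give the high numbers, so the rise does not depend on carboxy alone, and the step from compound 3 to compound 4 cannot be read because both compounds give a limit and not a number: the limit of > 250000 nM in this assay, at which 2 of the 4 values shown sit.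

As far as these compounds go, it remains open whether the phenyl ring itself drives the lower numbers, since a cyclohexyl ring or a plain butyl chain at the same place would separate a ring of carbon from an aromatic one. A simple methylcarbamoyl group or a primary amine would show whether the hydroxyethyl part or the carbonyl is needed for the rise.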